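Chloro step on compound 2: rat microsomal clearance notes

The source may report more compounds than this note shows. Statements on the series, on what has been measured and on what is new or still open speak of the compounds shown alone.

Measured so far:
- compound 1 `N#Cc1ccc(COc2cc3n(n2)CCCC3)nc1`: 42 mL.min-1.g-1
- compound 2 `N#Cc1ccc(CC(=O)c2cc3n(n2)CCCC3)nc1`: 108 mL.min-1.g-1

In an ADME assay on microsomes (Rattus norvegicus) for metabolic stability (a higher number here means faster removal of the compound, a lower number slower removal), compound 2 stands highest of the two measured compounds at 108 mL.min-1.g-1. Compound 1 gives a lower number at 42 mL.min-1.g-1, and this gap lies beyond the scatter. The two compounds do not form a single-place step, so their gap says nothing about the change considered next.

Compound 3 `N#Cc1ccc(CC(=O)c2nn3c(c2Cl)CCCC3)nc1` is still unmeasured. It differs from compound 2 by one change: chloro in place of hydrogen on an aromatic carbon. In words, this is chloro in place of hydrogen on an aromatic carbon. Going by the values given here, the series holds no measured pair showing the effect of this change in this assay, so neither direction is favoured. The expectation starts from compound 2 at 108 mL.min-1.g-1, with no step beyond the scatter. The estimated change is a 1.0-fold lower number from compound 2 to compound 3 (0.01 log units; within the scatter). Among the compounds with values here, the range is kept wide, as the series offers no direct precedent. For compound 3 the expected value is 105 mL.min-1.g-1, within an estimated range of 50 mL.min-1.g-1 to 210 mL.min-1.g-1.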

Compound 3, intrinsic clearance in microsomes: 649 mL.min-1.g-1
Estimate against measurement, compound 3: 6.2-fold (0.79 log units) below; the whole stated range lies below it.
By their numbers in this assay, from the lowest: compound 1; then compound 2; then compound 3.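

In this assay, going by these compounds alone, chloro in place of hydrogen on an aromatic carbon of the five-membered aromatic ring with 2 nitrogen gives a 6.0-fold higher number from compound 2 to compound 3 (0.78 log units; beyond the scatter) and so provides the first single-place step. The earlier pair differs in more than one place and could not isolate this position, whereas this step shows that a change of 1 heavy atom here, with no ring, no hydrogen-bond donor or acceptor and no net charge, is enough to move this assay beyond the scatter. No measurement at hand bears on the reason for this rise.

With chloro as the only replacement for hydrogen at this carbon, the compounds shown leave open whether the rise is particular to chloro or would also appear with fluoro, methyl or methoxy in the same place. They also leave open whether chloro at this carbon has a similar effect on the core of compound 1, where the link to the pyridine-bearing part differs from that in compound 2.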